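Replacing the acetyl group of compound 1

The compounds below may be only part of what the source reports. "The series", "measured", "known", "first", "only" and "open" are said of these compounds alone.

Among the measured compounds shown here, in an ADME assay on MT4 cells (Homo sapiens) for cytotoxicity, read by MTT assay, with a stated time of 96 h (a higher number here means that more compound is tolerated, a lower number that less compound is tolerated), compound 1 `COc1ccc(-c2nc3cc(C(C)=O)ccc3n2C2CCCCC2)cc1` gives 27000 nM, the middle of three numbers so far. It lies within the scatter of compound 2 `COc1ccc(-c2nc3cc(C(C)=O)ccc3n2C2CCCCC2)c(OC)c1` at 21000 nM. Compound 3 `CC(=O)c1ccc2c(c1)nc(-c1ccoc1)n2C1CCCCC1` gives 63000 nM, a higher number than that of compound 1.

The next compound, compound 4 `COc1ccc(-c2nc3cc(/C(C)=N/NC(N)=S)ccc3n2C2CCCCC2)cc1`, keeps the rest of compound 1 and alters one group: a group of 7 heavy atoms (3 carbon, 3 nitrogen, 1 sulfur; no ring) in place of a group of 3 heavy atoms (2 carbon, 1 oxygen; no ring), on an aromatic carbon. The acetyl group is thus replaced by a larger chain, which carries sulfur and more hydrogen-bond donors.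

Two measured steps start from compound 1. Methoxy in place of hydrogen gave a 1.3-fold lower number from compound 1 to compound 2 (0.11 log units; within the scatter), and furan-3-yl in place of 4-methoxyphenyl gave a 2.3-fold higher number from compound 1 to compound 3 (0.37 log units; beyond the scatter). Both are small, but neither touches the acetyl group, so they show only how far this short series has moved so far. For the measured compounds named here, no measured compound shows what a change at the acetyl group does, which leaves any forecast uncertain.

The new group is much larger than either earlier change, and the cautious expectation is a modest move towards less tolerated compound. The expected change is a 2.3-fold lower number from compound 1 to compound 4 (0.35 log units; beyond the scatter).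

The estimated value for compound 4 is 12000 nM, expected to fall between 3500 nM and 45000 nM.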

Compound 4, half-maximal cytotoxic concentration: 39000 nM
The estimate for compound 4 lay 3.3-fold (0.51 log units) below the measured number; the measured number falls inside the stated range.
By their numbers in this assay, from the lowest: compounds 2, 1, 4 and 3 (each within the scatter of the next, the first and the last beyond it).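

Among the compounds shown here, this is the first measured change at the acetyl group, on an aromatic carbon of the six-membered aromatic ring of the shared core. In this assay, a group of 7 heavy atoms with sulfur and 2 hydrogen-bond donors in place of the acetyl group gives a 1.4-fold higher number from compound 1 to compound 4 (0.16 log units; within the scatter), so on the core of compound 1 this position takes a much larger chain with no change that can be told from the scatter, and the acetyl oxygen is not needed to keep the number in this range. Nothing measured here gives a reason for this result.

A single pair cannot show whether this holds for other groups at this position, such as an amine, a carboxylic acid or a longer chain of carbon atoms, or whether it is particular to this sulfur-bearing chain. It also leaves open whether the same replacement would give a similar step on compound 3, which carries furan-3-yl in place of 4-methoxyphenyl.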